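The source may hold more compounds than are shown below. What is called first, only, known or untested is meant among the compounds shown, and "the series" means these compounds.

Two members of the series carry numbers in an ADME assay on cells for inhibition of Amine oxidase [flavin-containing] A (Homo sapiens), read by fluorescence and Amplex Red, with stated times of 30 min and 15 min; a lower number here means a stronger inhibitor, a higher number a weaker inhibitor. Compound 1 `C#CCNC1CCc2c(NCc3cccc(Br)c3)cccc21` gives 94300 nM in this assay. Compound 2 `C#CCNC1CCc2c(SCc3ccc(F)cc3)cccc21` is reported in this assay only as a limit, < 100 nM, not as a number; (the limit of < 100 nM in this assay, at which 1 of the 2 values shown sits). Among the compounds with values here, no step between two measured compounds is available here, so no measured change in this assay can be quoted for this pair of structures. Compound 3 `C#CCNC1CCc2c(SCc3ccc(Cl)cc3)cccc21` differs from compound 2 by chloro in place of fluoro on an aromatic carbon. For this change a step in this assay that stays within the usual scatter is expected, in either direction, with the outcome most likely again sitting at the limit. The step from compound 2 to compound 3 is estimated as a step that the limit leaves unreadable from compound 2 to compound 3. Compound 3 is expected to give about 60 nM in this assay, within 15 nM to 250 nM.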

Compound 3, half-maximal inhibitory concentration: 230 nM
Beside the measured number, compound 3's estimate is 3.8-fold (0.58 log units) below it; measured number inside the range.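

In this assay the change from 4-fluorophenyl to 4-chlorophenyl gives an at least 2.3-fold higher number from compound 2 to compound 3 (0.36 log units; beyond the scatter). A single exchange of one halogen for another on this aromatic carbon, with no ring, hydrogen-bond donor, hydrogen-bond acceptor or net charge entering or leaving, is therefore enough to register in this assay, something the earlier pair, which differs in more than one place, could not show. Compound 2 stands only as a limit, so the step can be read in one direction and its full size stays unknown: the limit of < 100 nM in this assay, at which 1 of the 3 values shown sits.

The compounds shown leave open how a 4-bromophenyl, a 4-methoxyphenyl or an unsubstituted phenyl would read at this position. They also leave open whether the same fluoro to chloro exchange would read alike with the nitrogen link of compound 1 in place of the sulfur.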